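Hydroxamic acid to carboxylic acid: rat exposure notes

This account rests on a few compounds, and the source may have more. Where it says the series, first, only, none or still open, it means among the compounds named here.

Values from an ADME assay on the whole organism (plasma) for pharmacokinetics, with Rattus norvegicus as the target, at a dose of 10 mg/kg by the intravenous route; a higher number here means more compound in the circulation at the dose given, a lower number less compound in the circulation:
compound 1, `C[C@@](CCc1ccc(-c2ccc(C#N)cc2)cc1)(C(=O)NO)S(C)(=O)=O`: 3100 ng.h/mL
compound 2, `C[C@@](CCc1ccc(-c2ccc(O)cc2)cc1)(C(=O)NO)S(C)(=O)=O`: 2500 ng.h/mL

Going by the values given here, the only measured step, a 1.2-fold lower number from compound 1 to compound 2 (0.09 log units; within the scatter), changes the substituent on the distal aromatic ring and leaves the hydroxamic acid untouched. Compound 2 and compound 1 therefore stand within the scatter of each other in this assay, and neither can be called higher or lower on the numbers shown.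

Compound 3, `C[C@@](CCc1ccc(-c2ccc(O)cc2)cc1)(C(=O)O)S(C)(=O)=O`, is the carboxylic acid analogue of compound 2. The change is hydroxy in place of hydroxyamino on a carbonyl carbon. Among the compounds with values here, no measured step touches this position: the step from compound 1 to compound 2 sits on the biaryl end of the molecule and says nothing about the carbonyl end. The expectation for compound 3 therefore rests on no shown step and is set wide. The estimated step is a 1.4-fold higher number from compound 2 to compound 3 (0.15 log units; within the scatter), a shift that would not be beyond the scatter with any confidence. Compound 3 is expected to give about 3500 ng.h/mL, with a range from 1200 ng.h/mL to 10000 ng.h/mL.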

Compound 3, area under the concentration-time curve: 10900 ng.h/mL
Estimate against measurement, compound 3: 3.1-fold (0.49 log units) below; measured number above the stated range.
By their numbers in this assay, from the lowest: compounds 2 and 1 (each within the scatter of the next); then compound 3.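

In this assay, the carbonyl end of the molecule proves to be a place where a single change moves the read-out: hydroxy in place of hydroxyamino on a carbonyl carbon gives a 4.4-fold higher number from compound 2 to compound 3 (0.64 log units; beyond the scatter), beyond the scatter, whereas the earlier change on an aromatic carbon, a 1.2-fold lower number from compound 1 to compound 2 (0.09 log units; within the scatter), stayed within it. Among the steps shown, hydroxycarbamoyl to carboxy is therefore the one that separates compounds in this measure, although this finding rests on a single pair sharing the hydroxy group on the aromatic ring. Nothing available bears on why the number rises with this change.

The compounds shown leave open whether the same change at the carbonyl carbon would give a comparable step with the nitrile of compound 1 on the aromatic ring in place of that hydroxy group. They also leave open how other groups on the carbonyl carbon, such as a primary amide or a methyl ester, would stand against the hydroxyamino and hydroxy groups in this assay.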